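The compounds below may be only part of what the source reports. "The series", "measured", "known", "first", "only" and "open" are said of these compounds alone.

Working notes on the series. In an ADME assay on HEK293 cells (Homo sapiens) for cytotoxicity, read by MTT assay, with a stated time of 48 h (on this read-out higher numbers stand for weaker inhibition and lower numbers for stronger inhibition), compound 1 `CCn1c(N)c(-c2nc3ccccc3[nH]2)c2nc(C#N)c(C#N)nc21` gives > 50000 nM, which is a limit of the assay. Compound 2 `CN(C)CCn1c(N)c(-c2nc3ccccc3[nH]2)c2nc(C#N)c(C#N)nc21` reads 9730 nM and compound 3 `CN1CCN(CCCn2c(N)c(-c3nc4ccccc4[nH]3)c3nc(C#N)c(C#N)nc32)CC1` reads 6260 nM. For the measured compounds named here, these are the only two true numbers so far, and the gap, a 1.6-fold lower number from compound 2 to compound 3 (0.19 log units; within the scatter), leaves compound 3 level with compound 2.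

Compound 4 `N#Cc1nc2c(-c3nc4ccccc4[nH]3)c(N)n(CCCO)c2nc1C#N` is not yet measured. It has hydroxy in place of 4-methylpiperazin-1-yl on a saturated chain carbon, three bonds along the chain from an aromatic nitrogen.

Going by the values given here, the steps that bear on this are an at least 5.1-fold lower number from compound 1 to compound 2 (0.71 log units; beyond the scatter) and an at least 7.9-fold lower number from compound 1 to compound 3 (0.90 log units; beyond the scatter). Among the compounds with values here, both add an amino group to the chain of compound 1, and compound 4 gives up the one in compound 3. A reversal of part of that size is therefore expected, towards a higher number in this assay. Within the data shown here, no measured compound carries hydroxy, so the size stays uncertain. The expected change is a 4.8-fold higher number from compound 3 to compound 4 (0.68 log units; beyond the scatter). For compound 4 the estimated value is 30000 nM, with an estimated range of 12000 nM to 60000 nM.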

Compound 4, half-maximal inhibitory concentration: > 50000 nM
Compound 4 gave a limit, no number; the forecaster's own chance of this, stated with the estimate: 40%; at least 1.6-fold (0.22 log units) between middle value and limit.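

With the 3-(4-methylpiperazin-1-yl)propyl chain replaced by 3-hydroxypropyl, this assay shows an at least 7.9-fold higher number from compound 3 to compound 4 (0.90 log units; beyond the scatter), and the comparison with the dimethylamino chain shows an at least 5.1-fold higher number from compound 2 to compound 4 (0.71 log units; beyond the scatter). In this set, the lower numbers therefore go with the two chains that end in an amine, while the chain ending in hydroxy does not share them, and no compound shown goes against this. The step from compound 1 to compound 4 cannot be read, as both values are limits: the limit of > 50000 nM in this assay, at which 2 of the 4 values shown sit.

As far as these compounds go, it remains open whether a primary amine or a morpholine at the chain end would read like compound 2 and compound 3, and whether a carboxylic acid there would read like compound 4. From the compounds shown here alone, how a longer chain carrying the dimethylamino group would read also remains open.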